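Sulfonyl for Hydrogen on the Ring Nitrogen of Compound 1

This account rests on a few compounds, and the source may have more. Where it says the series, first, only, none or still open, it means among the compounds named here.

Compound 1 `Fc1cccc(CNCc2c[nH]c3ccccc23)c1F` was tested in a functional assay on 3T3-L1 cells (Mus musculus) for inhibition, with a stated time of 20 min, tested at 20 uM (on this read-out lower numbers stand for less inhibition and higher numbers for more inhibition at the one concentration tested (going by the name of the read-out)), where compound 1 gives -1.7%. Going by the values given here, on the two numbers recorded this is the lowest, but the only other measured compound, compound 2 `Cc1ccc(S(=O)(=O)N(Cc2cn(Cc3ccccc3)nn2)Cc2cn(S(=O)(=O)c3ccc(C)cc3)c3ccccc23)cc1`, gives 3.4% in this assay, a value within the scatter of compound 1, so the two cannot be told apart. Both sit close to zero, which means neither shows inhibition that the measurement can distinguish from noise.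

Compound 3 `Cc1ccc(S(=O)(=O)n2cc(CNCc3cccc(F)c3F)c3ccccc32)cc1` has not yet been measured. It differs from compound 1 in one place: (4-methylphenyl)sulfonyl in place of hydrogen on an aromatic nitrogen. Among the compounds with values here, no measured pair in this set isolates such a change, so there is no step to read from. With both recorded values lying at the floor of the read-out, the step of a number 3.7 percentage points higher from compound 1 to compound 3 (within the scatter) is expected to stay within the scatter, in no particular direction. Compound 3 is therefore expected to give about 2% in this assay, with a range from -12% to 16%.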

Compound 3, a percentage reported as inhibition, at one concentration (the size of the read-out at that concentration, not a potency): 46%
The estimate for compound 3 lay 44 percentage points below the measured number, outside the stated range (above it).
By their numbers in this assay, from the lowest: compounds 1 and 2 (each within the scatter of the next); then compound 3.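

In this assay, the aromatic nitrogen of the five-membered ring proves to be a position where a change can move the read-out: (4-methylphenyl)sulfonyl in place of hydrogen comes out as a number 47.7 percentage points higher from compound 1 to compound 3 (beyond the scatter), a large step and the first result here to rise clear of the values near zero. Going by these compounds alone, this rests on a single pair, in which the hydrogen leaves and a group with a six-membered aromatic ring of carbon only and a sulfonyl enters, so the one step cannot separate the loss of that hydrogen from the arrival of the new group. No measurement shown here bears on why the number rises.

Going by these compounds, it remains open whether a smaller group on the same nitrogen, such as methyl, acetyl or methanesulfonyl, would give a similar step, or whether the 4-methylphenyl part is needed. Also open, on these data alone, is how much of the effect survives at other concentrations, since a reading at one concentration is not a potency, and whether a carboxylic acid or a methoxy group on the new aromatic ring would change it.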